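The compounds below may be only part of what the source reports. "The series", "measured", "known", "first", "only" and "open" are said of these compounds alone.

Compound 1 `Cc1ccc(-c2cn(C[C@H]3c4c(ccc(O)c4C)[C@@H]4CC[C@@]5(C)C[C@]43CC5=O)nn2)cc1`: in a functional assay on SMMC-7721 cells (Homo sapiens) for cytotoxicity, read by MTT assay, with a stated time of 4 days (a higher number here means a weaker inhibitor, a lower number a stronger inhibitor), compound 1 gives > 20000 nM, which is a limit of the assay.
Compound 2 `C=C1C[C@]23C[C@@]1(O)CC[C@H]2c1ccc(O)c(C)c1[C@@H]3Cn1cc(-c2ccc(OC)cc2)nn1`: in this assay compound 2 gives > 20000 nM, again a limit.
Compound 3 `C=C1C[C@]23C[C@@]1(O)CC[C@H]2c1ccc(O)c(C)c1[C@@H]3Cn1cc(-c2ccc(C)cc2)nn1`: in this assay compound 3 gives > 20000 nM, again a limit.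

Within the data shown here, every value so far sits at the limit of > 20000 nM in this assay, at which 3 of the 3 values shown sit. The step from compound 3 to compound 2, a step that the two limits leave unreadable from compound 3 to compound 2, is the change (methoxy in place of methyl on an aromatic carbon); since both ends are limits, its size cannot be read. Compound 1 and compound 3 are built from the same atoms joined differently, and the difference between the two cores is not broken down here.

Compound 4 `COc1ccc(-c2cn(C[C@H]3c4c(ccc(O)c4C)[C@@H]4CC[C@@]5(C)C[C@]43CC5=O)nn2)cc1` has not yet been measured in this assay. It differs from compound 1 by methoxy in place of methyl on an aromatic carbon, the same change as that from compound 3 to compound 2, made on a different core. Nothing measured separates the two ends of that change, so the expectation for compound 4 rests only on compound 1 and its limit > 20000 nM. The estimated step that the limit leaves unreadable from compound 1 to compound 4 is expected to be small. Compound 4 is therefore estimated at 30000 nM, expected to lie between 12000 nM and 100000 nM.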

Compound 4, half-maximal inhibitory concentration: > 20000 nM
Compound 4: a limit, no number; the forecaster's own chance of this, stated with the estimate: 90%; the middle value does not contradict the limit.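

Compound 1 and compound 4 both stand at a limit, so the change between them cannot be read and this result yields no new step: the limit of > 20000 nM in this assay, at which 4 of the 4 values shown sit.

The compounds shown leave open how strong any of them is in this assay, and whether methoxy in place of methyl on an aromatic carbon alters that on either core.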